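Fluoro for Carbamoyl, Repeated on a Second Core

The source may hold more compounds than are shown below. What is called first, only, known or untested is meant among the compounds shown, and "the series" means these compounds.

Compound 1, `C[C@H](Oc1cc2cc(C(N)=O)ccc2nc1N)c1cc(F)c(F)cc1-n1cccn1`, gives 3.2 in a physicochemical assay for lipophilicity, using the shake flask method; on this read-out lower numbers stand for lower lipophilicity and higher numbers for higher lipophilicity.
Compound 2, `C[C@H](Oc1cc2cc(F)ccc2nc1N)c1cc(F)c(F)cc1-n1cccn1`, gives 4.1 in this assay.
Compound 3, `C[C@H](Oc1cc2cc(C(N)=O)ccc2nc1N)c1cc2c(cnn2CCO)cc1-n1cccn1`, gives 2.1 in this assay.

Compound 4, `C[C@H](Oc1cc2cc(F)ccc2nc1N)c1cc2c(cnn2CCO)cc1-n1cccn1`, has not yet been measured. Its relation to compound 3 is fluoro in place of carbamoyl on an aromatic carbon. The same change links compound 1 and compound 2, namely (fluoro in place of carbamoyl on an aromatic carbon), and there it gave a number 0.90 log units higher from compound 1 to compound 2 (beyond the scatter). How the core of compound 3 differs from the core of compound 1 is not broken down here; compound 3 stands lowest of the three measured numbers in this assay, with compound 1 nearest and compound 2 furthest.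

Within the data shown here, since the place of the change is the same word for word in both pairs, the step from compound 3 to compound 4 is expected to be a number 0.90 log units higher from compound 3 to compound 4 (beyond the scatter), resting on the single earlier example because compound 1 to compound 2 gave a number 0.90 log units higher from compound 1 to compound 2 (beyond the scatter). With one example only, the expected range is kept wide. Compound 4 is therefore estimated at 3 in this assay, between 2.5 and 3.5.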

Compound 4, distribution coefficient: 3.3
Compound 4: the middle estimate sits 0.30 log units below what was measured; the measured number falls inside the stated range.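

In this assay the replacement of carbamoyl by fluoro on the aromatic carbon gave a number 1.20 log units higher from compound 3 to compound 4 (beyond the scatter) and, on the core of compound 1, a number 0.90 log units higher from compound 1 to compound 2 (beyond the scatter); the change has now gone the same way on both cores shown. Two pairs show only that the direction held in these four compounds: they do not show how the size of the step depends on the core, nor that the step would carry over to any further core. No measurement shown here accounts for the direction of the step or for its size.

The compounds shown leave open whether another replacement for carbamoyl at this place, such as a nitrile, an amine or a carboxylic acid, would give a step of the same direction. They also leave open how the change would behave on a core carrying a longer chain or a morpholine ring in the part that separates the two cores.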